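The source may report more compounds than this note shows. Statements on the series, on what has been measured and on what is new or still open speak of the compounds shown alone.

Compound 1 `COC(=O)NC12CCC(n3cc(-c4ccc(Cl)c(N)c4)c4c(N)ncnc43)(CC1)CC2`: 70600 ng.h/mL
Compound 2 `COC(=O)N[C@H]1CC[C@@H](n2cc(-c3ccc(Cl)c(N)c3)c3c(N)ncnc32)CC1`: 49800 ng.h/mL

In an ADME assay on the whole organism (Mus musculus, strain BALB/c) for pharmacokinetics, read by LC-MS, at a dose of 10 mg/kg by the oral route (on this read-out higher numbers stand for higher exposure at the dose given and lower numbers for lower exposure), compound 1 gives 70600 ng.h/mL and compound 2 gives 49800 ng.h/mL. These two numbers lie within the usual scatter of each other, so compound 1 stands level with compound 2 on the evidence so far.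

Compound 3 `COC(=O)NC12CCC(n3cc(-c4cc(N)c(Cl)cc4F)c4c(N)ncnc43)(CC1)CC2` keeps the whole of compound 1 except for one change on the aromatic ring: fluoro in place of hydrogen on an aromatic carbon. In words, this is fluoro in place of hydrogen on an aromatic carbon. Within the data shown here, no pair of measured compounds shows this change, so the data give no direction for it. The expectation therefore starts from compound 1 at 70600 ng.h/mL, with no step beyond the scatter in this assay. The estimated change is a 1.2-fold lower number from compound 1 to compound 3 (0.07 log units; within the scatter). For compound 3 the expected value is 60000 ng.h/mL, with an estimated range from 25000 ng.h/mL to 130000 ng.h/mL.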

Compound 3, area under the concentration-time curve: 73400 ng.h/mL
The estimate for compound 3 lay 1.2-fold (0.09 log units) below the measured number; low and high end bracket the measured number.
By their numbers in this assay, from the lowest: compounds 2, 1 and 3 (each within the scatter of the next).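

In this assay, fluoro in place of hydrogen gives a 1.0-fold higher number from compound 1 to compound 3 (0.02 log units; within the scatter), so compound 1 and compound 3 stand level. Among these compounds, until now no pair showed this change; this pair shows that, on this aromatic carbon, ortho to a large group, meta to a chloro group and para to an amino group, a fluoro leaves the exposure within the scatter of the parent. This is one pair at one position, and nothing measured here speaks to why the two stand level.

Going by these compounds, whether a nitrile or a methoxy group on this same carbon would also stay level remains open. So does whether fluoro on another carbon of this ring, or the same fluoro on the ring of compound 2, would behave as it does here.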